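The compounds below may be only part of what the source reports. "The series", "measured", "known", "first", "only" and "open" are said of these compounds alone.

Series notes, values in a functional assay on A549 cells (Homo sapiens) for antiproliferative activity, read by MTT assay, with a stated time of 48 h; on this read-out higher numbers stand for weaker inhibition and lower numbers for stronger inhibition:

- compound 1 `O=C(/C=C/c1ccc(F)cc1)Nc1nnc(-c2ccc(Br)cc2)s1`: 2.83 ug/mL
- compound 2 `O=C(/C=C/c1ccc(F)cc1)Nc1nnc(-c2ccccc2)s1`: 1.82 ug/mL
- compound 3 `O=C(/C=C/c1ccc(C(F)(F)F)cc1)Nc1nnc(-c2ccc(Cl)cc2)s1`: 3.09 ug/mL

Compound 3, at 3.09 ug/mL, stands within the scatter of both compound 1 and compound 2, so the three numbers form one tight group with no order to be read from them.

The next compound is compound 4 `O=C(/C=C/c1ccc(F)cc1)Nc1nnc(-c2ccc(Cl)cc2)s1`, which has fluoro in place of trifluoromethyl on an aromatic carbon.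

Going by the values given here, no measured step makes this exchange directly, so the size of this change in this assay has not been seen. Among the compounds with values here, the only measured step is a different exchange, hydrogen in place of bromo on an aromatic carbon, and it gives a 1.6-fold lower number from compound 1 to compound 2 (0.19 log units; within the scatter). It shows one substitution in this small set that does not move the number beyond the scatter. Compound 1 and compound 2 also already carry the fluoro group that enters, and compound 1 gives 2.83 ug/mL while compound 2 gives 1.82 ug/mL.

No step beyond the scatter is therefore expected in this assay, and no firm direction can be claimed. The expected change is a 1.3-fold lower number from compound 3 to compound 4 (0.11 log units; within the scatter). For compound 4 the estimated value is 2.4 ug/mL, with an expected range of 1.3 ug/mL to 4.3 ug/mL.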

Compound 4, half-maximal inhibitory concentration: 2.06 ug/mL
For compound 4 the middle estimate is 1.2-fold (0.07 log units) above the measured one; the range from low to high includes it.
By their numbers in this assay, from the lowest: compounds 2, 4, 1 and 3 (each within the scatter of the next).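

Replacing trifluoromethyl with fluoro on an aromatic carbon para to a large group now has a measured size in this assay, with a 1.5-fold lower number from compound 3 to compound 4 (0.18 log units; within the scatter) on this pair, so the smaller group is accepted here without a move beyond the scatter. With fluoro held fixed at that position, the substituent on the other aromatic ring can now be compared across hydrogen, chloro and bromo: chloro in place of hydrogen gives a 1.1-fold higher number from compound 2 to compound 4 (0.05 log units; within the scatter) and chloro in place of bromo gives a 1.4-fold lower number from compound 1 to compound 4 (0.14 log units; within the scatter), so these three substituents do not separate in this assay. Nothing available here bears on why all of these steps stay so small.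

From the compounds shown here alone, the fluoro for trifluoromethyl exchange has been read only with chloro on the other ring, so it remains open whether the same small step holds with hydrogen or bromo there. Going by these compounds, with every step inside the scatter, it also remains open whether either position can move the number at all, which an amine or a carboxylic acid in place of fluoro would test.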